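One methyl moved, two amide substituents compared

The source may hold more compounds than are shown below. What is called first, only, known or untested is meant among the compounds shown, and "the series" means these compounds.

Three compounds sharing one core were examined in an assay on HEK293 cells for displacement of a labelled ligand from metabotropic glutamate receptor 5 (Homo sapiens), with a stated time of 2 h; a higher number here means a weaker inhibitor, a lower number a stronger inhibitor. Compound 1 `Cc1ccccc1C#Cc1ccc2c(n1)CCN(C(C)C)C2=O` carries isopropyl on the amide-type nitrogen in a ring and 2-methylphenyl on the triple-bonded carbon. In this assay compound 1 gives only a limit, > 32000 nM. Compound 2 `Cc1cccc(C#Cc2ccc3c(n2)CCN(C(C)C)C3=O)c1` differs from compound 1 by 3-methylphenyl in place of 2-methylphenyl on a triple-bonded carbon, and in this assay compound 2 gives 510 nM. The change produced an at least 62-fold lower number from compound 1 to compound 2 (1.79 log units; beyond the scatter). Compound 3 `Cc1ccccc1C#Cc1ccc2c(n1)CCN(C1CCCCC1)C2=O` differs from compound 1 by cyclohexyl in place of isopropyl on an amide-type nitrogen in a ring. In this assay compound 3 gives only a limit, > 32000 nM. The step that the two limits leave unreadable from compound 1 to compound 3 because of the limit of > 32000 nM in this assay, at which 2 of the 3 values shown sit.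

Compound 4 `Cc1cccc(C#Cc2ccc3c(n2)CCN(C2CCCCC2)C3=O)c1` remains unmeasured. It differs from compound 3 by 3-methylphenyl in place of 2-methylphenyl on a triple-bonded carbon, the same change as that from compound 1 to compound 2, made on a core whose difference is given by cyclohexyl in place of isopropyl on an amide-type nitrogen in a ring. Since compound 3 sits at the limit, the same change is expected to produce an at least 32-fold lower number from compound 3 to compound 4 (1.50 log units; beyond the scatter), resting on an at least 62-fold lower number from compound 1 to compound 2 (1.79 log units; beyond the scatter). Compound 4 is therefore estimated at 1000 nM, between 200 nM and 15000 nM.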

Compound 4, inhibition constant: 3210 nM
Estimate against measurement, compound 4: 3.2-fold (0.51 log units) below, within the range that was stated.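

In this assay, 3-methylphenyl in place of 2-methylphenyl on a triple-bonded carbon again gave a lower number with cyclohexyl on the amide-type nitrogen, an at least 9.9-fold lower number from compound 3 to compound 4 (0.99 log units; beyond the scatter), so the direction of the change carried over between these two cores, although the size of the gain cannot be compared: the same change on two cores in this assay, an at least 62-fold lower number (1.79 log units; beyond the scatter) from compound 1 to compound 2 and an at least 9.9-fold lower number (0.99 log units; beyond the scatter) from compound 3 to compound 4; the limit leaves it open whether they differ With 3-methylphenyl in place, cyclohexyl in place of isopropyl gave a 6.3-fold higher number from compound 2 to compound 4 (0.80 log units; beyond the scatter), whereas the same swap with 2-methylphenyl cannot be read: the limit of > 32000 nM in this assay, at which 2 of the 4 values shown sit. Two cores show agreement in direction only, and they do not establish a rule for the series.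

The compounds shown leave open whether the change would carry over with other groups on the amide-type nitrogen, such as cyclopropyl or benzyl. They also leave open how an unsubstituted phenyl or 4-methylphenyl on the triple-bonded carbon would compare with 3-methylphenyl.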